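Swapping Chloro for Trifluoromethyl on a Shared Core

This account rests on a few compounds, and the source may have more. Where it says the series, first, only, none or still open, it means among the compounds named here.

Of the compounds shown here, two that share a core have been tested in a functional assay on the whole organism for inhibition, with Rattus norvegicus as the target, at a dose of 30 mg/kg; a lower number here means less inhibition, a higher number more inhibition at the dose given (going by the name of the read-out). Compound 1 `N#Cc1ccccc1-c1nc2cccnc2o1` gives 61% in this assay. Compound 2 `Clc1ccccc1-c1nc2ncccc2o1` gives 38% in this assay, the lower of the two numbers, and its gap to compound 1 lies beyond the usual scatter of repeated measurements. The two compounds differ in more than one place, so that gap cannot be tied to any single change in structure.

Compound 3 `FC(F)(F)c1ccccc1-c1nc2ncccc2o1` has not yet been measured. It differs from compound 2 by one exchange: trifluoromethyl in place of chloro on an aromatic carbon. Within the data shown here, no pair of measured compounds isolates this exchange, and neither measured compound carries a trifluoromethyl group, so nothing among the known values points to a direction. The expected step is a number 2 percentage points higher from compound 2 to compound 3 (within the scatter), which is not expected to go beyond the scatter either way. Among the measured compounds shown here, compound 3 is therefore estimated to give 40% in this assay, within a range from 15% to 65%, resting on the value of compound 2 as the only close comparison available.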

Compound 3, a percentage reported as inhibition, in the whole organism at one dose (the size of the read-out at that dose, not a potency): 19%
Compound 3: the middle estimate sits 21 percentage points above what was measured, within the range that was stated.
By their numbers in this assay, from the lowest: compound 3; then compound 2; then compound 1.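

In this assay, among these compounds, trifluoromethyl in place of chloro on an aromatic carbon, ortho to a group of 9 heavy atoms, gives a number 19 percentage points lower from compound 2 to compound 3 (beyond the scatter) and is the first step here that can be tied to a single change in structure. The earlier gap between compound 1 and compound 2 could not do this, since those two compounds differ in more than one place, whereas this pair shows that inhibition at the dose given responds to what sits at this position and that the two groups cannot be treated as interchangeable there. The step shows that the exchange matters but not the reason, and no measurement available here bears on why the number falls.

The compounds shown cover only chloro and trifluoromethyl on this core, so they leave open how an amine, a carboxylic acid or a longer chain at this position would read in this assay and where such groups would fall relative to these two. They also leave open whether the same exchange would lower the number on the core of compound 1, where a nitrile stands on the aromatic ring instead.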